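The source may hold more compounds than are shown below. What is called first, only, known or untested is meant among the compounds shown, and "the series" means these compounds.

Measured so far:
compound 1 `O=C(O)c1cc(-c2cccc(COc3ccc4c(=O)n(CC5CC5)sc4c3)c2)ccc1Cl`: 38.4%
compound 2 `O=C1c2ccc(OCc3cccc(-c4ccccc4)c3)cc2CN1C1CCCC1`: "not determined" (no result reported)
compound 3 `O=C1c2ccc(OCc3cccc(-c4ccc(C(F)(F)F)cc4F)c3)cc2CN1C1CCCC1`: "not determined" (no result reported)

For the measured compounds named here, in an assay on HEK293 cells for positive allosteric modulation of metabotropic glutamate receptor 2 (Rattus norvegicus), read by thallium flux (on this read-out lower numbers stand for smaller maximal responses and higher numbers for larger maximal responses), compound 1 gives 38.4% and is the only compound of the series with a number; compound 2 and compound 3 carry no result there, so no step between measured compounds can be drawn.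

Compound 4 `CC(C)CCn1sc2cc(OCc3cccc(-c4ccc(Cl)c(C(=O)O)c4)c3)ccc2c1=O` is not yet measured. It differs from compound 1 as isobutyl in place of cyclopropyl on a saturated chain carbon bound to an aromatic nitrogen. The core and the acid-bearing biaryl ether side are unchanged; only the group on the saturated chain carbon bound to the aromatic nitrogen changes. Going by the values given here, no measured pair shows the effect of such a change, so the expectation rests on compound 1 alone.

The step from a number 1.6 percentage points higher from compound 1 to compound 4 (within the scatter) is expected to stay within the scatter, with no clear direction. Compound 4 is estimated at 40% in this assay, between 22% and 62%.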

Compound 4, largest response reached (reported as percent of maximum), in percent of the reference or control that the assay uses: 67.3%
For compound 4 the middle estimate is 27.3 percentage points below the measured one; the whole stated range lies below it.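

In this assay, the group on the saturated chain carbon bound to an aromatic nitrogen proves to be a position that moves the maximal response: isobutyl in place of cyclopropyl gives a number 28.9 percentage points higher from compound 1 to compound 4 (beyond the scatter). The open chain is therefore accepted here, with the shared core and the acid-bearing side unchanged. Nothing available explains the step.

This single pair changes the ring and the carbon count together, so their contributions cannot be separated. Going by these compounds, how a longer chain or a cyclobutyl ring would read at this place remains open.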